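Replacing the 3-hydroxy-4-methylphenyl group of compound 2

The source may hold more compounds than are shown below. What is called first, only, known or untested is meant among the compounds shown, and "the series" means these compounds.

Measured in a functional assay on HepG2 cells (Homo sapiens) for antiproliferative activity, read by MTT assay, with a stated time of 48 h; a lower number here means a stronger inhibitor, a higher number a weaker inhibitor:
compound 1 `COc1ccc(-c2c(Nc3ccc(F)cc3)c3ccc(OC)cc3oc2=O)cc1`: > 100000 nM
compound 2 `COc1ccc(-c2c(Nc3ccc(C)c(O)c3)c3ccc(OC)cc3oc2=O)cc1`: 22500 nM

The entry of compound 1 is the limit of > 100000 nM in this assay, at which 1 of the 2 values shown sits. For the measured compounds named here, compound 2 therefore holds the only actual number so far. Compound 3 `CCOc1ccc(Nc2c(-c3ccc(OC)cc3)c(=O)oc3cc(OC)ccc23)cc1` has 4-ethoxyphenyl in place of 3-hydroxy-4-methylphenyl on a nitrogen on an aromatic ring, (4-ethoxyphenyl in place of 3-hydroxy-4-methylphenyl on a nitrogen on an aromatic ring). Going by the values given here, the one measured step at that place is an at least 4.4-fold lower number from compound 1 to compound 2 (0.64 log units; beyond the scatter). With the 3-hydroxy-4-methylphenyl group leaving again, a modest step towards a higher number is expected in this assay. The expected change is a 2.7-fold higher number from compound 2 to compound 3 (0.43 log units; beyond the scatter). For compound 3 the estimated value is 60000 nM, with an expected range of 20000 nM to 100000 nM.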

Compound 3, half-maximal inhibitory concentration: 31200 nM
Compound 3: the middle estimate sits 1.9-fold (0.28 log units) above what was measured, and the stated range covers the measured number.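

In this assay, 4-ethoxyphenyl and 3-hydroxy-4-methylphenyl on the nitrogen give a 1.4-fold higher number from compound 2 to compound 3 (0.14 log units; within the scatter) and so cannot be told apart, although 4-ethoxyphenyl carries no hydrogen-bond donor. Ethoxy in place of fluoro gives an at least 3.2-fold lower number from compound 1 to compound 3 (0.50 log units; beyond the scatter) and so shows that a hydroxy group on this ring is not needed for a separation from compound 1. This step is only a bound, because compound 1 stands at a limit of the assay: the limit of > 100000 nM in this assay, at which 1 of the 3 values shown sits.

Open, on these data alone, is whether an amine, a carboxylic acid or a longer chain in place of ethoxy on this ring would move the number beyond the scatter.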